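Sulfonyl aryl swap on a second core

This account rests on a few compounds, and the source may have more. Where it says the series, first, only, none or still open, it means among the compounds named here.

Compound 1 `Cc1ccc(S(=O)(=O)c2cnc3cc(Cl)ccc3c2N2CCC(C)CC2)cc1F` and compound 2 `CC1CCN(c2c(S(=O)(=O)c3ccc(C#N)cc3)cnc3cc(Cl)ccc23)CC1` share one core; in an assay on isolated protein for displacement of a labelled ligand from metabotropic glutamate receptor 5 (Homo sapiens), with a stated time of 60 min, tested at 1 uM (on this read-out higher numbers stand for more inhibition at the one concentration tested (going by the name of the read-out) and lower numbers for less inhibition), compound 1 gives 85% and compound 2 gives 70%. The change 3-fluoro-4-methylphenyl in place of 4-cyanophenyl on a sulfonyl sulfur gives a number 15 percentage points higher from compound 2 to compound 1 (beyond the scatter). Compound 3 `Cc1ccc2ncc(S(=O)(=O)c3ccc(C#N)cc3)c(N3CCC(C)CC3)c2c1` sits on a different core; the difference between the two cores is not broken down here. In this assay compound 3 gives 55%, the lowest of the three. Compound 4 `Cc1ccc2ncc(S(=O)(=O)c3ccc(C)c(F)c3)c(N3CCC(C)CC3)c2c1` carries the same change on this core, (3-fluoro-4-methylphenyl in place of 4-cyanophenyl on a sulfonyl sulfur), at a place described in the same words as before. Going by the values given here, the expectation for compound 4 is a step of a number 15 percentage points higher from compound 3 to compound 4 (beyond the scatter), resting on the one earlier step of a number 15 percentage points higher from compound 2 to compound 1 (beyond the scatter), with only one such pair measured. In this assay compound 4 is estimated at 70%, between 55% and 85%.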

Compound 4, a percentage reported as inhibition, at one concentration (the size of the read-out at that concentration, not a potency): 91%
For compound 4 the middle estimate is 21 percentage points below the measured one; the measured number lies above the stated range.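

In this assay the change to 3-fluoro-4-methylphenyl in place of 4-cyanophenyl on a sulfonyl sulfur again goes upward on the second core, with a number 36 percentage points higher from compound 3 to compound 4 (beyond the scatter), so the direction carries over between these two cores. The size does not carry over: the same change on two cores in this assay, a number 15 percentage points higher (beyond the scatter) from compound 2 to compound 1 and a number 36 percentage points higher (beyond the scatter) from compound 3 to compound 4, 21 percentage points apart, beyond the scatter of two such steps. With one pair per core and a read-out at a single concentration rather than a potency, this gives no rule for other cores and no reason for the gap between the two steps.

From the compounds shown here alone, whether a sulfonyl aryl group carrying a carboxylic acid or an amine would move in the same direction on both cores stays open. So does whether any other aryl group on the sulfonyl sulfur would show the same dependence on the core.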